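A few compounds are considered here, and "the series" means these few. Any claim that something is new, unique, unknown or untested is made for them only; others in the source may bear on it.

In a functional assay on DU-145 cells (Homo sapiens) for cytotoxicity, read by sulforhodamine B assay, with a stated time of 48 h (on this read-out lower numbers stand for stronger inhibition and higher numbers for weaker inhibition), compound 1 `C[C@H]1CC[C@@H]2[C@@H](OC(=O)[C@]23CC(c2ccccc2)=NO3)[C@]2(C)C(=O)C=C[C@@]12O` gives 39800 nM, compound 2 `C[C@H]1CC[C@@H]2[C@@H](OC(=O)[C@]23CC(c2ccc(O)cc2)=NO3)[C@]2(C)C(=O)C=C[C@@]12O` gives 93000 nM and compound 3 `C[C@H]1CC[C@@H]2[C@@H](OC(=O)[C@]23CC(c2ccccc2[N+](=O)[O-])=NO3)[C@]2(C)C(=O)C=C[C@@]12O` gives 34000 nM. Compound 3 is therefore level with compound 1 within the scatter, and both stand clearly below compound 2. Compound 4 `Cc1ccccc1C1=NO[C@]2(C1)C(=O)O[C@@H]1[C@H]2CC[C@H](C)[C@]2(O)C=CC(=O)[C@@]12C` differs from compound 3 at one place: methyl in place of nitro on an aromatic carbon. This puts methyl in place of nitro on an aromatic carbon. Among the measured compounds shown here, no measured step makes this exact swap. The closest guide is a 1.2-fold lower number from compound 1 to compound 3 (0.07 log units; within the scatter), where adding nitro made no real difference, whereas a 2.3-fold higher number from compound 1 to compound 2 (0.37 log units; beyond the scatter) is only modest. No step beyond the scatter is therefore expected, and the estimated change is a 1.2-fold higher number from compound 3 to compound 4 (0.07 log units; within the scatter). For compound 4 the expected value is 40000 nM, with an estimated range of 18000 nM to 85000 nM.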

Compound 4, half-maximal inhibitory concentration: 12000 nM
For compound 4 the middle estimate is 3.3-fold (0.52 log units) above the measured one; measured number outside the range, below it.
By their numbers in this assay, from the lowest: compound 4; then compounds 3 and 1 (each within the scatter of the next); then compound 2.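

The group on this aromatic carbon can clearly shift the number: in this assay, methyl gives a 2.8-fold lower number from compound 3 to compound 4 (0.45 log units; beyond the scatter), although nitro had made no real difference relative to hydrogen. Methyl also improves on hydrogen, with a 3.3-fold lower number from compound 1 to compound 4 (0.52 log units; beyond the scatter), and the 2-methylphenyl group improves on 4-hydroxyphenyl, with a 7.8-fold lower number from compound 2 to compound 4 (0.89 log units; beyond the scatter). Among these compounds, then, the identity of the group matters, and methyl gives the lowest number.

Nothing available here explains why methyl gives a lower number than nitro. As far as these compounds go, whether an ethyl group, a methoxy group or an amine at this place would lower the number further remains open.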